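The compounds below may be only part of what the source reports. "The series", "measured", "known", "first", "only" and "open" are said of these compounds alone.

Measured so far:
- compound 1 `Cc1ccnc2nc(-c3cccc(Cl)c3)cc(O)c12`: 2340 nM
- compound 2 `Cc1cc(C)c2c(O)cc(-c3cccc(Cl)c3)nc2n1`: 3090 nM

Both values come from a functional assay on cells (Panel prostate (Carcinoma cell lines), Homo sapiens) for inhibition; on this read-out lower numbers stand for stronger inhibition of growth and higher numbers for weaker inhibition of growth. Compound 1 has a single neighbour on this scale, compound 2, and the two lie within the scatter of each other.

Compound 3 `Oc1cc(-c2cccc(Cl)c2)nc2ncccc12` has not yet been measured. It differs from compound 1 as follows: hydrogen in place of methyl on an aromatic carbon. This is hydrogen in place of methyl on an aromatic carbon, opposite the ring nitrogen.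

Going by the values given here, only one measured step bears on this change, and it adds a methyl on an aromatic carbon: a 1.3-fold higher number from compound 1 to compound 2 (0.12 log units; within the scatter). That is a small step, but it is a single one at a different carbon, so it offers only limited guidance. No shift beyond the scatter is therefore expected in this assay, and no direction can be favoured. The expected step is a 1.1-fold higher number from compound 1 to compound 3 (0.03 log units; within the scatter). Compound 3 is estimated at 2500 nM, with an expected range from 1200 nM to 5000 nM.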

Compound 3, concentration for total growth inhibition: 2630 nM
Beside the measured number, compound 3's estimate is 1.1-fold (0.02 log units) below it; the measured number falls inside the stated range.
By their numbers in this assay, from the lowest: compounds 1, 3 and 2 (each within the scatter of the next).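

In this assay the loss of the methyl opposite the ring nitrogen gives a 1.1-fold higher number from compound 1 to compound 3 (0.05 log units; within the scatter) and so provides a measured step at this carbon itself, where the earlier pair spoke only for a methyl on a different aromatic carbon. Hydrogen and methyl at this position cannot be told apart on this read-out, so the methyl of compound 1 is not required for the growth inhibition seen here. No measurement given here speaks to the reason for so small a step.

The compounds shown carry only hydrogen or methyl at this carbon, so it remains open whether an amine, a carboxylic acid or a longer chain would shift the number beyond the scatter. As far as these compounds go, it is also open whether the same indifference to methyl holds when the shared core carries other groups elsewhere.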